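The source may hold more compounds than are shown below. What is called first, only, known or untested is meant among the compounds shown, and "the series" means these compounds.

Compound 3 `Cc1cc(C(=O)O)nn1Cc1cc(Br)ccc1OCc1ccc(Cl)cc1` is measured in a functional assay on CHO-K1 cells for antagonist activity at prostaglandin E2 receptor EP1 subtype (Homo sapiens), read by FLIPR (a lower number here means a stronger inhibitor, a higher number a weaker inhibitor), where compound 3 gives 8.71 nM, the lowest of the two numbers available. Compound 1 `CCCCc1cc(C(=O)O)nn1Cc1cc(Br)ccc1OCc1ccccc1` gives 977 nM in this assay. Compound 2 `O=C(O)c1cnn(Cc2cc(Br)ccc2OCc2ccccc2)c1` reaches only a limit of the assay and no number: in this assay compound 2 gives < 2000 nM, a limit of the kind noted as the limit of < 2000 nM in this assay, at which 1 of the 3 values shown sits. Compound 4 `Cc1cc(C(=O)O)nn1Cc1cc(Br)ccc1OCc1cccc(Br)c1` has not yet been measured in this assay. It differs from compound 3 in one place: 3-bromophenyl in place of 4-chlorophenyl on a saturated chain carbon bound to an oxygen on an aromatic ring. Within the data shown here, no measured pair shows this change, so the expected step from compound 3 to compound 4 in this assay is estimated as small, near a 1.7-fold higher number from compound 3 to compound 4 (0.24 log units; within the scatter), possibly a slight weakening. Compound 4 is therefore expected to give about 15 nM, estimated between 4 nM and 60 nM.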

Compound 4, inhibition constant: 129 nM
For compound 4 the middle estimate is 8.6-fold (0.93 log units) below the measured one; measured number outside the range, above it.
By their numbers in this assay, from the lowest: compound 3; then compound 4; then compound 1.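

Among these compounds, this is the first measured pair to change the aromatic ring on a saturated chain carbon bound to an oxygen on an aromatic ring, and it shows that this place is sensitive in this assay. Replacing 4-chlorophenyl with 3-bromophenyl, which has the same heavy-atom count, gives a 15-fold higher number from compound 3 to compound 4 (1.17 log units; beyond the scatter). Nothing shown gives a reason for this step.

The pair changes both the halogen and its ring position, so their contributions cannot be separated. A 3-chlorophenyl or 4-bromophenyl group would be needed to tell which change matters.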